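Swapping Chlorines for Methoxy Groups on a Growth Inhibitor

A few compounds are considered here, and "the series" means these few. Any claim that something is new, unique, unknown or untested is made for them only; others in the source may bear on it.

Three pyrazole-linked compounds have been tested in a functional assay on NCI-H322M cells (Homo sapiens) for inhibition, read by sulforhodamine B assay, with a stated time of 48 h; a lower number here means a stronger inhibitor of growth, a higher number a weaker inhibitor of growth. Compound 1 `COc1ccc(-c2cc(/C=C/C(=O)c3ccc(OC)c(OC)c3)[nH]n2)cc1` gives 1620 nM, compound 3 `COc1ccc(-c2cc(/C=C/C(=O)c3ccc(N)cc3)[nH]n2)cc1` gives 1840 nM, and compound 2 `COc1cc(-c2cc(/C=C/C(=O)c3ccc(Cl)c(Cl)c3)[nH]n2)cc(OC)c1OC` gives 14500 nM. Compound 2 thus stands at the highest number of the three, which means it is the weakest inhibitor of growth in this assay; its nearest neighbour on the scale is compound 3, and the gap to both compound 3 and compound 1 lies beyond the usual scatter.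

Compound 4 `COc1ccc(C(=O)/C=C/c2cc(-c3cc(OC)c(OC)c(OC)c3)n[nH]2)cc1OC` has not yet been measured. It differs from compound 2 in one place: 3,4-dimethoxyphenyl in place of 3,4-dichlorophenyl on a carbonyl carbon. Compound 1 also carries a 3,4-dimethoxyphenyl on a carbonyl carbon, and in this assay compound 1 gives 1620 nM, a clearly lower number than compound 2. On that basis the step from compound 2 to compound 4 is expected to go downward, toward stronger growth inhibition, by more than the scatter, as a 5.8-fold lower number from compound 2 to compound 4 (0.76 log units; beyond the scatter). Because compound 1 gives 1620 nM, compound 4 is estimated at 2500 nM in this assay, with a plausible range from 1000 nM to 7000 nM.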

Compound 4, concentration for 50% growth inhibition: 1520 nM
For compound 4 the middle estimate is 1.6-fold (0.22 log units) above the measured one, and the stated range covers the measured number.
By their numbers in this assay, from the lowest: compounds 4, 1 and 3 (each within the scatter of the next); then compound 2.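

In this assay, among the compounds shown here, the change of 3,4-dichlorophenyl to 3,4-dimethoxyphenyl on a carbonyl carbon gives a 9.5-fold lower number from compound 2 to compound 4 (0.98 log units; beyond the scatter), and this is the first step that can be read at a single place, as no two of the earlier compounds formed such a pair. With the rest of compound 2 kept as it is, this one exchange is enough to carry the number well beyond the scatter, so the high number of compound 2 depends on the group at this place and not on the rest of the molecule alone. Nothing measured here accounts for the size of this step, so it stands as an observation without an explanation.

This single pair cannot tell whether the step follows from the loss of the chlorines or the arrival of the methoxy groups, and a plain phenyl ring at this place, or a phenyl ring carrying a carboxylic acid, would help to separate the two. On these data alone, whether the same step would appear on a different core, or outside this assay, also stays open.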